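The compounds below may be only part of what the source reports. "The series", "measured", "known", "first", "only" and "open" are said of these compounds alone.

Measured so far:
Compound 1, `CCOC(=O)C(C)(C)ON1C(=O)c2ccccc2C1=O`: 95%
Compound 2, `CCCC(C)ON1C(=O)c2ccccc2C1=O`: 56%

In a functional assay on the whole organism for inhibition, with Lepidium sativum as the target, tested at 100 ppm (a higher number here means more inhibition of growth at the concentration tested, a lower number less inhibition of growth), compound 2 gives 56%, the lower of the two numbers; compound 1 gives 95%, a gap beyond the scatter. Compound 3, `CCOC(=O)C(C)ON1C(=O)c2ccccc2C1=O`, has not been measured. It differs from compound 2 in one place: ethoxycarbonyl in place of propyl on a saturated chain carbon bound to an oxygen on an unsaturated carbon and a saturated chain carbon. Among the compounds with values here, no measured pair shows this change on its own, but compound 1, which also carries an ethoxycarbonyl, gives 95%, so an upward step beyond the scatter is expected. The estimated step is a number 24 percentage points higher from compound 2 to compound 3 (beyond the scatter). Compound 3 is expected to give 80%, within a range from 55% to 95%.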

Compound 3, percent growth inhibition at one concentration: 100%
Beside the measured number, compound 3's estimate is 20 percentage points below it; the whole stated range lies below it.
By their numbers in this assay, from the lowest: compound 2; then compounds 1 and 3 (each within the scatter of the next).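

Ethoxycarbonyl in place of propyl on this saturated chain carbon now has a step of its own in this assay (a number 44 percentage points higher from compound 2 to compound 3 (beyond the scatter)), so this single change brings a large gain in growth inhibition. Hydrogen in place of methyl on that same carbon gives a step within the scatter (a number 5 percentage points higher from compound 1 to compound 3 (within the scatter)), so compounds with and without that methyl cannot be told apart here. Nothing shown here bears on the cause of either step. From the compounds shown here alone, it remains open whether a carboxylic acid or an amide at this place would hold the inhibition seen with ethoxycarbonyl.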